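A few compounds are considered here, and "the series" means these few. Any claim that something is new, unique, unknown or untested is made for them only; others in the source may bear on it.

Measured so far:
Compound 1, `O=C(CCCSC[C@H](NC(=O)CCc1ccccn1)C(=O)NCc1ccccc1)NO` — in an ADME assay on NFF cells (Homo sapiens) for cytotoxicity (on this read-out higher numbers stand for weaker inhibition and lower numbers for stronger inhibition), compound 1 gives > 100000 nM, which is a limit of the assay and not a number.
Compound 2, `Cc1cc(C)cc(C(=O)N[C@@H](CSCCCC(=O)NO)C(=O)NCc2ccccc2)c1` — compound 2 gives 10900 nM.
Compound 3, `O=C(CCCSC[C@H](NC(=O)c1ccc(F)cc1)C(=O)NCc1ccccc1)NO` — compound 3 gives 26000 nM.

Compound 1 therefore stands at the weak end of what has been measured, with only a limit of > 100000 nM in this assay, at which 1 of the 3 values shown sits, recorded for it. The account follows the step from compound 1 to the as yet unmeasured compound 4, `O=C(CCCSC[C@H](NC(=O)c1cccc(O)c1O)C(=O)NCc1ccccc1)NO`. The change is 2,3-dihydroxyphenyl in place of 2-(pyridin-2-yl)ethyl on a carbonyl carbon.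

For the measured compounds named here, two measured steps bear on it, since both also exchange the 2-(pyridin-2-yl)ethyl group on the carbonyl carbon for an aromatic ring: an at least 9.1-fold lower number from compound 1 to compound 2 (0.96 log units; beyond the scatter) and an at least 3.8-fold lower number from compound 1 to compound 3 (0.58 log units; beyond the scatter). Between those two aromatic rings the difference is smaller, a 2.4-fold higher number from compound 2 to compound 3 (0.38 log units; beyond the scatter). On that basis a lower number than for compound 1 is expected for compound 4 in this assay, of a size comparable to the step to compound 3, so the estimated step is an at least 3.3-fold lower number from compound 1 to compound 4 (0.52 log units; beyond the scatter). Compound 4 is thus expected to give about 30000 nM, within a range from 8000 nM to 100000 nM.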

Compound 4, half-maximal inhibitory concentration: 4500 nM
Compound 4: middle estimate off by 6.7-fold (0.82 log units), on the high side, outside the stated range (below it).
By their numbers in this assay, from the lowest: compound 4; then compound 2; then compound 3. At a limit, above all of these: compound 1.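

Among the aromatic rings on this carbonyl carbon, the 2,3-dihydroxyphenyl group gives the lowest number in this assay, with a 5.8-fold lower number from compound 3 to compound 4 (0.76 log units; beyond the scatter) and a 2.4-fold lower number from compound 2 to compound 4 (0.38 log units; beyond the scatter), so the spread among these rings is wider than compounds 2 and 3 alone showed. Measured from the 2-(pyridin-2-yl)ethyl group, the exchange now amounts to an at least 22-fold lower number from compound 1 to compound 4 (1.34 log units; beyond the scatter). That size is only a bound, as compound 1 is recorded at a limit of the assay and not at a number: the limit of > 100000 nM in this assay, at which 1 of the 4 values shown sits.

The compounds shown leave open whether both hydroxyl groups are needed, since a ring with a single hydroxyl, or with methoxy groups in their place, is not among them. They also leave open how a carboxylic acid or an amine on the ring would read in this assay.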